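Three flat analogues and one untested ring-amine substituent

The compounds below may be only part of what the source reports. "The series", "measured", "known", "first", "only" and "open" are said of these compounds alone.

compound 1 `Nc1scc(CN2CCN(c3cccc(C(F)(F)F)c3)CC2)c1C(=O)c1ccc(Cl)cc1`: 0%
compound 2 `Nc1scc(CN2CCC(c3ccc(Cl)cc3)CC2)c1C(=O)c1ccc(Cl)cc1`: 0%
compound 3 `Nc1scc(CN2CCN(c3cccc(F)c3)CC2)c1C(=O)c1cccc(C(F)(F)F)c1`: 0%

All three were run in an assay on CHO cells for displacement of a labelled ligand from adenosine receptor A1 (Homo sapiens), read by scintillation counting, with a stated time of 120 min, tested at 10 uM; a lower number here means less inhibition, a higher number more inhibition at the concentration tested (going by the name of the read-out). Compound 1 gives 0%, level with compound 2 at 0% and with compound 3 at 0%, every pair within the scatter, so no ordering among them can be drawn.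

Compound 4 `Nc1scc(CN2CCN(c3cc(F)cc(F)c3)CC2)c1C(=O)c1ccc(Cl)cc1` has not been measured. It differs from compound 1 in one place:
3,5-difluorophenyl in place of 3-(trifluoromethyl)phenyl on an amine nitrogen in a ring
Among the compounds with values here, no step between two measured compounds is available, so the expectation rests only on the three flat values. The step of no change at the digits printed from compound 1 to compound 4 (within the scatter) is expected to be none beyond the scatter. For compound 4 the estimate is 0%, with a range from 0% to 10%.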

Compound 4, a percentage reported as inhibition, at one concentration (the size of the read-out at that concentration, not a potency): 0%
Compound 4: the middle estimate sits on the measured number at the digits printed; the measured number falls inside the stated range.
By their numbers in this assay, from the lowest: compounds 1, 2, 3 and 4 (each within the scatter of the next).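

Within the data shown here, the exchange of 3-(trifluoromethyl)phenyl for 3,5-difluorophenyl on an amine nitrogen in a ring gives the first one-place step: in this assay it reads no change at the digits printed from compound 1 to compound 4 (within the scatter). With no inhibition at either end of the step, it does not separate the two groups, and a smaller group with one fluorine more leaves the read-out flat. Nothing measured on these compounds offers an explanation for this result.

Open, on these data alone, is whether an amine or a carboxylic acid on this phenyl ring, or a longer chain in its place, gives any measurable inhibition in this assay.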